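Methylating the aminopyridine of compound 1: an expectation

The source may report more compounds than this note shows. Statements on the series, on what has been measured and on what is new or still open speak of the compounds shown alone.

Compound 1 `CCOc1cc(CN2CCC(NC(=O)c3ccc(N)nc3)CC2)cc(OCC)c1-c1ccc(F)cc1` gives 7.86 in a physicochemical assay for acid dissociation, read by spectrophotometry. Compound 3 `CCOc1cc(CN2CCC(NC(=O)c3cncc(C)c3)CC2)ccc1-c1ccc(F)cc1` gives 7.87 and compound 2 `CCOc1cc(CN2CCC(NC(=O)c3ccc(N)nc3)CC2)cc(OCc2ccccc2)c1-c1ccc(F)cc1` gives 7.66, so compound 1 stands second highest of the three, within the scatter of both. Within the data shown here, the only measured step, a number 0.20 log units lower from compound 1 to compound 2 (within the scatter), changes a different part of the molecule. Compound 4 `CCOc1cc(CN2CCC(NC(=O)c3ccc(NC)nc3)CC2)cc(OCC)c1-c1ccc(F)cc1` differs from compound 1 by methyl in place of hydrogen on a nitrogen on an aromatic ring. Among the measured compounds shown here, no measured step touches this nitrogen, so the expectation rests on the small spread seen across compounds 1 to 3. A step of a number 0.04 log units higher from compound 1 to compound 4 (within the scatter) is expected, within the scatter. Compound 4 is therefore estimated at 7.9, between 7.5 and 8.3.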

Compound 4, acid dissociation constant: 7.86
Estimate against measurement, compound 4: 0.04 log units above, and the stated range covers the measured number.
By their numbers in this assay, from the lowest: compounds 2, 1, 4 and 3 (each within the scatter of the next).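

In this assay, among these compounds, methyl in place of hydrogen on this nitrogen gives no change at the digits printed from compound 1 to compound 4 (within the scatter), the first measured step at this position. Going from amino to methylamino therefore stays within the scatter here, something the only earlier step could not show, since it lay in a different part of the molecule. No evidence bears on why the read-out holds steady at this nitrogen. Still open, from the compounds shown here alone, is whether a longer chain such as ethyl, a second methyl giving dimethylamino, or an acetyl group on this nitrogen would also stay within the scatter.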